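A Larger Group on the Aromatic Nitrogen

The source may hold more compounds than are shown below. What is called first, only, known or untested is meant among the compounds shown, and "the series" means these compounds.

Compound 1 `CCn1nc(C)c2c1NC(=O)CN=C2c1ccccc1Cl` and compound 2 `Cc1nn(C(C)C)c2c1C(c1ccccc1Cl)=NCC(=O)N2` share one core and were both tested in a functional assay on the whole organism with Rattus norvegicus as the target; on this read-out higher numbers stand for an effect only at larger amounts of compound and lower numbers for an effect already at smaller amounts. Compound 1 gives 8 mg/kg, and compound 2 gives 16 mg/kg, the higher of the two numbers, though a 2.0-fold higher number from compound 1 to compound 2 (0.30 log units; within the scatter) keeps that gap within the scatter. Compound 3 `Cc1nn(C2CCCCC2)c2c1C(c1ccccc1Cl)=NCC(=O)N2` differs from compound 2 by cyclohexyl in place of isopropyl on an aromatic nitrogen. Within the data shown here, the only measured step that bears on this change is a 2.0-fold higher number from compound 1 to compound 2 (0.30 log units; within the scatter), and it was small, so the step of a 1.3-fold higher number from compound 2 to compound 3 (0.10 log units; within the scatter) is expected to stay within the scatter. Compound 3 is therefore estimated at 20 mg/kg, with a range from 8 mg/kg to 50 mg/kg.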

Compound 3, minimum effective dose: > 500 mg/kg
Compound 3 was reported as a limit (the forecaster's own chance of this, stated with the estimate: 10%); middle value at least 25-fold (1.39 log units) away from the limit.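

On this aromatic nitrogen, cyclohexyl in place of isopropyl gives an at least 31-fold higher number from compound 2 to compound 3 (1.49 log units; beyond the scatter), and cyclohexyl in place of ethyl gives an at least 62-fold higher number from compound 1 to compound 3 (1.79 log units; beyond the scatter). Ethyl and isopropyl lie within the scatter of each other, so only this new step shows that the position is not indifferent to which carbon group it carries. The value of compound 3 in this assay is a limit, not a number: the limit of > 500 mg/kg in this assay, at which 1 of the 3 values shown sits.

Going by these compounds, what remains open is whether this jump belongs to cyclohexyl alone or also appears with a smaller ring such as cyclopropyl, a flat ring such as phenyl, or an open chain such as n-butyl.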